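Benzyl group swap from compound 3 to compound 4

The compounds below may be only part of what the source reports. "The series", "measured", "known", "first", "only" and "open" are said of these compounds alone.

Measured so far in a functional assay on Jurkat cells (Homo sapiens); a lower number here means a stronger inhibitor, a higher number a weaker inhibitor:
- compound 1 `C[C@H](NC(=O)C(=O)NCC1(c2ccccc2)CC1)C(=O)N[C@@H](CC(=O)O)C(=O)COc1c(F)c(F)cc(F)c1F` gives 27 nM
- compound 2 `Cc1ccccc1CNC(=O)C(=O)N[C@@H](C)C(=O)N[C@@H](CC(=O)O)C(=O)COc1c(F)c(F)cc(F)c1F` gives 52 nM
- compound 3 `Cc1ccc(CNC(=O)C(=O)N[C@@H](C)C(=O)N[C@@H](CC(=O)O)C(=O)COc2c(F)c(F)cc(F)c2F)cc1` gives 50 nM

Compound 3 stands within the scatter of both other compounds, with a 1.0-fold lower number from compound 2 to compound 3 (0.02 log units; within the scatter) and a 1.9-fold higher number from compound 1 to compound 3 (0.27 log units; within the scatter) as the steps that reach it. Compound 4 `C[C@H](NC(=O)C(=O)NCc1cccc(Cl)c1Cl)C(=O)N[C@@H](CC(=O)O)C(=O)COc1c(F)c(F)cc(F)c1F` carries 2,3-dichlorophenyl in place of 4-methylphenyl on a saturated chain carbon bound to an amide-type nitrogen. Every measured step bears on this place, and a 1.9-fold higher number from compound 1 to compound 2 (0.28 log units; within the scatter) also stays inside the scatter. No measured compound carries chlorine, so the effect of this particular change is not shown directly. Resting on compound 3 at 50 nM and on the small steps around it, only a minor change is expected. The expected move is a 1.3-fold lower number from compound 3 to compound 4 (0.10 log units; within the scatter) in size, with no shift beyond the scatter anticipated. For compound 4 the estimated value is 40 nM with an expected range of 15 nM to 110 nM in this series.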

Compound 4, half-maximal inhibitory concentration: 76 nM
For compound 4 the middle estimate is 1.9-fold (0.28 log units) below the measured one; measured number inside the range.
By their numbers in this assay, from the lowest: compounds 1, 3, 2 and 4 (each within the scatter of the next, the first and the last beyond it).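

In this assay, among the compounds shown here, the place on a saturated chain carbon bound to an amide-type nitrogen takes 2,3-dichlorophenyl, the first chlorine-bearing group in the set, and the two smaller steps stay inside the scatter: a 1.5-fold higher number from compound 3 to compound 4 (0.18 log units; within the scatter) and a 1.5-fold higher number from compound 2 to compound 4 (0.16 log units; within the scatter). Swapping methyl-bearing rings for the dichlorinated ring therefore gives no separable shift in this assay. For the compounds shown here, the step to the 1-phenylcyclopropyl compound, a 2.8-fold higher number from compound 1 to compound 4 (0.45 log units; beyond the scatter), is modest but is the first at this place to pass beyond the scatter, so a difference between two groups at this place can now be read.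

No measurement on hand accounts for these numbers.

From the compounds shown here alone, whether a single chlorine gives the same reading as the two in compound 4 remains open. So does how a carboxylic acid or an amine on the benzyl ring would read at this place.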